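Methoxy on the anilino ring: expected effect in the series

The compounds below may be only part of what the source reports. "The series", "measured", "known", "first", "only" and "open" are said of these compounds alone.

Measured so far:
compound 1 `Cc1nc(SCC(=O)Nc2nc(-c3ccc(Cl)cc3)cs2)n(Nc2ccccc2)c1C` 6270 nM
compound 2 `Cc1ccc(Nn2c(SCC(=O)Nc3nc(-c4ccccc4)cs3)nc(C)c2C)cc1` 6670 nM

In a functional assay on MDA-MB-468 cells (Homo sapiens) for antiproliferative activity, read by sulforhodamine B assay, with a stated time of 48 h (on this read-out higher numbers stand for weaker inhibition of growth and lower numbers for stronger inhibition of growth), compound 1 gives 6270 nM and compound 2 gives 6670 nM; the two values lie within the scatter of one another, so no order between them is claimed. Compound 3 `COc1ccc(Nn2c(SCC(=O)Nc3nc(-c4ccc(Cl)cc4)cs3)nc(C)c2C)cc1` differs from compound 1 by methoxy in place of hydrogen on an aromatic carbon, para to a large group. Among the measured compounds shown here, no measured pair isolates this change. Compound 3 is expected to remain close to compound 1 in this assay, with an estimated step of a 1.0-fold lower number from compound 1 to compound 3 (0.02 log units; within the scatter) not beyond the scatter. Compound 3 is therefore estimated at 6000 nM, range 2500 nM to 15000 nM.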

Compound 3, concentration for total growth inhibition: 7730 nM
Estimate against measurement, compound 3: 1.3-fold (0.11 log units) below; low and high end bracket the measured number.
By their numbers in this assay, from the lowest: compounds 1, 2 and 3 (each within the scatter of the next).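

In this assay, methoxy in place of hydrogen on the anilino ring, para to a large group, now has its first isolated reading (a 1.2-fold higher number from compound 1 to compound 3 (0.09 log units; within the scatter)). This single pair shows that phenyl to 4-methoxyphenyl at this position produces no step beyond the scatter. No measurement available here bears on this result.

As far as these compounds go, whether an amine or a carboxylic acid at this position would produce a step beyond the scatter remains open. Also open, from the compounds shown here alone, is how a longer chain in place of the methoxy would read.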